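The compounds below may be only part of what the source reports. "The series", "measured", "known", "first", "only" and "open" are said of these compounds alone.

In a toxicity assay on J774.A1 cells (Mus musculus) for cytotoxicity, read by SYBR Green assay, with a stated time of 1 h (a lower number here means that less compound is needed, a higher number that more compound is needed for the effect), compound 1 `CNc1ccc2cc(-c3cc(Cl)cc(Cl)c3)c(N)nc2c1` gives 3700 nM, and compound 2 `Nc1nc2cc(N3CCCC3)ccc2cc1-c1cc(Cl)cc(Cl)c1` gives 1400 nM in this assay. The change from compound 1 to compound 2 is pyrrolidin-1-yl in place of methylamino on an aromatic carbon, and it made a 2.6-fold lower number from compound 1 to compound 2 (0.42 log units; beyond the scatter). Compound 3 `CNc1ccc2cc(-c3cn(C)c4ccccc34)c(N)nc2c1` gives 4100 nM in this assay; its number and that of compound 1 lie within the scatter of each other. The difference between the core of compound 1 and the core of compound 3 is not broken down here. Compound 4 `Cn1cc(-c2cc3ccc(N4CCCC4)cc3nc2N)c2ccccc21` has not yet been measured. The change from compound 3 to compound 4 is pyrrolidin-1-yl in place of methylamino on an aromatic carbon, the same change at the same place as before. Because the same change earlier gave a 2.6-fold lower number from compound 1 to compound 2 (0.42 log units; beyond the scatter), a step of similar size is expected, a 2.4-fold lower number from compound 3 to compound 4 (0.38 log units; beyond the scatter). This rests on one earlier pair only. Compound 4 is therefore estimated at 1700 nM in this assay.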

Compound 4, half-maximal effective concentration: 440 nM
For compound 4 the middle estimate is 3.9-fold (0.59 log units) above the measured one; measured number below the stated range.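

In this assay, putting pyrrolidin-1-yl in place of methylamino on the core of compound 3 gave a 9.3-fold lower number from compound 3 to compound 4 (0.97 log units; beyond the scatter). The change lowered the number on both cores, but the size of the step did not carry over: the same change on two cores in this assay, a 2.6-fold lower number (0.42 log units; beyond the scatter) from compound 1 to compound 2 and a 9.3-fold lower number (0.97 log units; beyond the scatter) from compound 3 to compound 4, 3.5-fold (0.55 log units) apart, beyond the scatter of two such steps. A step measured on one core therefore cannot simply be copied to another in this series, although two pairs do not show why the sizes differ or what a third core would give.

The compounds shown leave open whether another cyclic amine in the same place, such as piperidine or morpholine, would follow pyrrolidin-1-yl. They also leave open whether an open-chain amine with longer chains, such as diethylamino, would do the same.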